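Swapping a Pyridylmethyl for a Pyrimidinyl on the Ring Amine

The source may report more compounds than this note shows. Statements on the series, on what has been measured and on what is new or still open speak of the compounds shown alone.

Of the compounds shown here, three built on one shared core have been measured in a functional assay on A-375 cells (Homo sapiens) for antiproliferative activity, read by CCK-8 assay, with a stated time of 72 h, tested at 2 uM; a higher number here means a stronger effect of the compound at the concentration tested, a lower number a weaker effect. Compound 1, with the structure `Nc1ccccc1NC(=O)c1ccc(CSC(=S)N2CCN(Cc3ccccn3)CC2)cc1`, gives 20.7% in this assay. Compound 2, `Nc1ccccc1NC(=O)c1ccc(CSC(=S)N2CCc3ccc([N+](=O)[O-])cc32)cc1`, gives 22.1%, and compound 3, `Nc1ccccc1NC(=O)c1ccc(CSC(=S)N2CCCc3ccccc32)cc1`, gives 26.5%. Compound 1 has the lowest of the three numbers, but its gaps to compound 2 and to compound 3 both lie within the usual scatter of such measurements, so nothing separates the three.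

Compound 4, `Nc1ccccc1NC(=O)c1ccc(CSC(=S)N2CCN(c3ncccn3)CC2)cc1`, has not yet been measured. It differs from compound 1 in one place: pyrimidin-2-yl in place of (pyridin-2-yl)methyl on an amine nitrogen in a ring. Within the data shown here, no pair of measured compounds shows the effect of a change like this. The three measured compounds carry quite different groups at this end of the molecule and still land within the scatter of one another.

The step from compound 1 to compound 4 is therefore expected to be a number 1.3 percentage points higher from compound 1 to compound 4 (within the scatter), nothing beyond the scatter in either direction. Compound 4 is estimated to give 22%, with a range from 10% to 36%.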

Compound 4, a percentage reported as inhibition, at one concentration (the size of the read-out at that concentration, not a potency): 24%
Compound 4: middle estimate off by 2 percentage points, on the low side, within the range that was stated.
By their numbers in this assay, from the lowest: compounds 1, 2, 4 and 3 (each within the scatter of the next).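

In this assay, placing pyrimidin-2-yl in place of (pyridin-2-yl)methyl on the amine nitrogen in the ring gives a number 3.3 percentage points higher from compound 1 to compound 4 (within the scatter), so this first direct reading at the position shows no effect that can be separated from ordinary variation. The two compounds therefore cannot be told apart, whether the aromatic ring is the one in (pyridin-2-yl)methyl, with one hetero atom, or the one in pyrimidin-2-yl, with two. Nothing available here helps explain this result.

Because the entering and leaving groups differ in more than one feature, this single step cannot show what each feature contributes on its own. As far as these compounds go, it also remains open whether a benzyl group, which has no ring nitrogen, or a small acetyl group without any aromatic ring would give a clearly different reading at this nitrogen.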